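Moving the Tetrazole Attachment Point in Two Related Series

The source may hold more compounds than are shown below. What is called first, only, known or untested is meant among the compounds shown, and "the series" means these compounds.

Measured compounds:
compound 1, `CCCCCCCCc1ccc(OCC(=O)Cn2cnnn2)cc1`: 39 nM
compound 2, `CCCCCCCCc1ccc(OCC(=O)Cn2ncnn2)cc1`: 10 nM
compound 3, `CC(Oc1ccc(-c2ccccc2)cc1)C(=O)Cn1cnnn1`: 19 nM

Of the compounds shown here, three have been tested in an assay on microsomes from brain for inhibition of Fatty-acid amide hydrolase 1 (Rattus norvegicus), read by fluorescence and HPLC, with a stated time of 60 min (a higher number here means a weaker inhibitor, a lower number a stronger inhibitor), and a fourth, compound 4 with the structure `CC(Oc1ccc(-c2ccccc2)cc1)C(=O)Cn1ncnn1`, awaits measurement. In this assay compound 1 gives 39 nM, compound 2 gives 10 nM, and compound 3 gives 19 nM. Compound 3 sits closest to compound 2, within the scatter of the method, while its gap to compound 1 lies beyond it.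

Compounds 1 and 2 share a core and differ only by 2H-tetrazol-2-yl in place of 1H-tetrazol-1-yl on a saturated chain carbon bound to a carbonyl carbon. That change produced a 3.9-fold lower number from compound 1 to compound 2 (0.59 log units; beyond the scatter), a modest but real step toward stronger inhibition. Compound 4 bears exactly the same change relative to compound 3, namely (2H-tetrazol-2-yl in place of 1H-tetrazol-1-yl on a saturated chain carbon bound to a carbonyl carbon), at the same kind of position, described in identical words for both pairs. The two cores themselves differ in more than one place, and that difference is not broken down here.

For the measured compounds named here, with only one earlier instance of this change, the expectation for compound 4 rests on that single step. Compound 4 is therefore estimated at 6 nM, meaning a step of a 3.2-fold lower number from compound 3 to compound 4 (0.50 log units; beyond the scatter), because the same change gave a 3.9-fold lower number from compound 1 to compound 2 (0.59 log units; beyond the scatter). The expected range for compound 4 runs from 2.5 nM to 15 nM, allowing for the possibility that a different core does not carry the change over fully.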

Compound 4, half-maximal inhibitory concentration: 9 nM
Beside the measured number, compound 4's estimate is 1.5-fold (0.18 log units) below it; the range from low to high includes it.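

In this assay, putting 2H-tetrazol-2-yl in place of 1H-tetrazol-1-yl on a saturated chain carbon bound to a carbonyl carbon gave a 2.1-fold lower number from compound 3 to compound 4 (0.32 log units; beyond the scatter), so the change again moved the number toward stronger inhibition. Set beside the earlier pair, the two steps run the same way, and the gap between their sizes does not exceed what repeated measurements would allow: the same change on two cores in this assay, a 3.9-fold lower number (0.59 log units; beyond the scatter) from compound 1 to compound 2 and a 2.1-fold lower number (0.32 log units; beyond the scatter) from compound 3 to compound 4, 1.8-fold (0.27 log units) apart, within the scatter of two such steps. This shows that the change carried over from the core of compound 1 to the core of compound 3 in direction, with no detectable difference in size, but two pairs in one assay do not show that it would hold on any further core, and they do not explain why the attachment point matters.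

The compounds shown leave open whether the same step would appear with a methyl group or an amine added to the tetrazole, or with a triazole or an imidazole standing in its place. They also leave open which of the several differences between the two cores, if any, bears on the size of the step, since those differences are not separated here.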